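Compound 3 to Compound 4: One Group Exchanged

The compounds below may be only part of what the source reports. "The series", "measured", "known", "first", "only" and "open" are said of these compounds alone.

In an ADME assay on microsomes from liver (Homo sapiens) for metabolic stability, using NADPH, with a stated time of 10 min (a lower number here means that less of the compound is left, a higher number that more of the compound is left), compound 1 (`CN(C[C@H]1Cc2c(cccc2N2CCC(N)CC2)CN1)[C@H]1CCCc2cccnc21`) gives 80.8% and compound 2 (`CN(C)[C@H]1CCN(c2cccc3c2C[C@H](CN(C)[C@H]2CCCc4cccnc42)NC3)C1`) gives 67.5%, while compound 3 (`CN(C[C@H]1Cc2c(cccc2N2C[C@H]3CCN(C)[C@H]3C2)CN1)[C@H]1CCCc2cccnc21`) stands highest of the three at 97.6% on this scale. Compound 4 (`CN(C[C@H]1Cc2c(cccc2N[C@H]2CC[C@H](N)CC2)CN1)[C@H]1CCCc2cccnc21`) has not been measured yet, and it differs from compound 3 in one group: a group of 8 heavy atoms (6 carbon, 2 nitrogen; one six-membered non-aromatic ring of carbon only) in place of a group of 9 heavy atoms (7 carbon, 2 nitrogen; 2 five-membered non-aromatic rings with 1 hetero atom each), on an aromatic carbon. The entering group is (4-aminocyclohexyl)amino, on an aromatic carbon.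

Exchanges of the group at this carbon have already given a number 13.3 percentage points lower from compound 1 to compound 2 (beyond the scatter) and a number 16.8 percentage points higher from compound 1 to compound 3 (beyond the scatter), and the largest was a number 30.1 percentage points higher from compound 2 to compound 3 (beyond the scatter) in this set. For the measured compounds named here, only compound 3 carries the two five-membered rings, and no measured compound carries a ring of carbon only here. The six-membered ring of compound 1 at 80.8% looks like the closest guide, though an imperfect one.

A downward step beyond the scatter is expected, an estimated a number 22.6 percentage points lower from compound 3 to compound 4 (beyond the scatter) in this assay. The expected value for compound 4 is 75% (52% to 92%).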

Compound 4, percent of the compound remaining: 100%
Compound 4: the middle estimate sits 25 percentage points below what was measured; the whole stated range lies below it.
By their numbers in this assay, from the lowest: compound 2; then compound 1; then compounds 3 and 4 (each within the scatter of the next).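

In this assay, the exchange at this aromatic carbon gives a number 2.4 percentage points higher from compound 3 to compound 4 (within the scatter) and so shows that the two five-membered rings of compound 3 are not needed for a reading this high: (4-aminocyclohexyl)amino, with one six-membered ring of carbon only and 2 hydrogen-bond donors in place of 0, reads level with them. The same entering group gives a number 19.2 percentage points higher from compound 1 to compound 4 (beyond the scatter) and a number 32.5 percentage points higher from compound 2 to compound 4 (beyond the scatter), so a six-membered ring at this place can read well above the 4-aminopiperidin-1-yl group of compound 1. Nothing among the data explains why these numbers fall as they do.

From the compounds shown here alone, whether the amine on the cyclohexyl ring matters stays open, and (4-hydroxycyclohexyl)amino at this carbon would speak to that. Going by these compounds, whether the nitrogen that joins this ring to the aromatic carbon matters stays open as well.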